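Working notes: from compound 1 to compound 4

The source may report more compounds than this note shows. Statements on the series, on what has been measured and on what is new or still open speak of the compounds shown alone.

Measured in a functional assay on MCF7 cells (Homo sapiens) for antiproliferative activity, read by MTT assay, with a stated time of 24 h; on this read-out higher numbers stand for weaker inhibition and lower numbers for stronger inhibition
compound 1 `O=[N+]([O-])c1ccc(S(=O)(=O)n2c(-c3cn(-c4ccccc4)nc3-c3ccc(F)cc3)nc3ccccc32)cc1` gives 1370 nM
compound 2 `O=S(=O)(c1ccc(Cl)cc1)n1c(-c2cn(-c3ccccc3)nc2-c2ccc(F)cc2)nc2ccccc21` gives 4960 nM
compound 3 `O=S(=O)(c1ccc(Br)cc1)n1c(-c2cn(-c3ccccc3)nc2-c2ccc(F)cc2)nc2ccccc21` gives 2630 nM

Compound 1 lies clearly under compound 2 and within the scatter of compound 3. Compound 4 `O=[N+]([O-])c1ccc(S(=O)(=O)n2c(-c3cn(-c4ccccc4)nc3-c3ccc(C(F)(F)F)cc3)nc3ccccc32)cc1` differs from compound 1 at one place trifluoromethyl in place of fluoro on an aromatic carbon with trifluoromethyl in place of fluoro on an aromatic carbon, para to a large group. Among the measured compounds shown here, no measured step touches that place. Size can only be borrowed from changes elsewhere, namely a 3.6-fold higher number from compound 1 to compound 2 (0.56 log units; beyond the scatter) and a 1.9-fold higher number from compound 1 to compound 3 (0.28 log units; within the scatter) and a 1.9-fold lower number from compound 2 to compound 3 (0.28 log units; within the scatter) in this series. No step beyond the scatter is therefore expected in this assay and any drift is expected toward a higher number. The estimate is a 1.4-fold higher number from compound 1 to compound 4 (0.14 log units; within the scatter) for now. Compound 4 is estimated at 1900 nM within an expected range of 750 nM to 4800 nM for this measurement.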

Compound 4, half-maximal inhibitory concentration: 1130 nM
Compound 4: middle estimate off by 1.7-fold (0.23 log units), on the high side, and the stated range covers the measured number.
By their numbers in this assay, from the lowest: compounds 4, 1, 3 and 2 (each within the scatter of the next, the first and the last beyond it).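

In this assay, among the compounds shown here, the change from 4-fluorophenyl to 4-(trifluoromethyl)phenyl gives a 1.2-fold lower number from compound 1 to compound 4 (0.08 log units; within the scatter) and stays within the scatter, the first reading at this place, since the earlier steps touched only the nitro, chloro and bromo site. This place therefore accepts trifluoromethyl in place of fluoro with no readable change in the number, at least alongside the nitro group. No available measurement offers an explanation for this result. From the compounds shown here alone, whether an amine or a carboxylic acid at this place would leave the number as flat remains open, as does whether trifluoromethyl behaves the same alongside chloro or bromo.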